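Arylsulfonyl hydroxamates as bone morphogenetic protein 1 inhibitors

The source may report more compounds than this note shows. Statements on the series, on what has been measured and on what is new or still open speak of the compounds shown alone.

Working notes on a set of sulfonamide-linked hydroxamic acids sharing one core; the compounds differ only in the group carried on the sulfonamide nitrogen. Among the measured compounds shown here, measured in an assay on isolated protein for inhibition of bone morphogenetic protein 1 (Homo sapiens) (a lower number here means a stronger inhibitor, a higher number a weaker inhibitor), compound 1 `COc1ccc(S(=O)(=O)N(CCn2cccc2)[C@H](C)C(=O)NO)cc1` gives 170 nM, which is the highest of the three numbers so far. Compound 2 `COc1ccc(S(=O)(=O)N(Cc2sc3scc(C)c3c2C)[C@H](C)C(=O)NO)cc1` gives 60 nM in this assay, a number beyond the scatter below that of compound 1. Compound 3 `COc1ccc(S(=O)(=O)N(Cc2cccc3ccccc23)[C@H](C)C(=O)NO)cc1` gives 90 nM in this assay, and its gap to compound 1 lies within the scatter, so no order between compound 1 and compound 3 can be read.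

The step to compound 4 `COc1ccc(S(=O)(=O)N(Cc2ccc(SC)cc2)[C@H](C)C(=O)NO)cc1` changes the nitrogen substituent of compound 1 as follows: 4-(methylsulfanyl)phenyl in place of (1H-pyrrol-1-yl)methyl on a saturated chain carbon bound to a sulfonamide nitrogen. For the measured compounds named here, no measured pair separated by a single change is available, so the direction can only be judged from the picture above, in which the two compounds carrying a larger aromatic group on this position behave as follows: compound 2 with 60 nM lies beyond the scatter below compound 1, while compound 3 with 90 nM lies within the scatter of compound 1. A modest move in the same direction is expected, around the edge of the scatter, so that compound 4 is estimated to show a step of a 1.8-fold lower number from compound 1 to compound 4 (0.25 log units; within the scatter) in this assay. Compound 4 is therefore expected to give about 95 nM, with a range from 40 nM to 230 nM.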

Compound 4, half-maximal inhibitory concentration: 80 nM
Beside the measured number, compound 4's estimate is 1.2-fold (0.07 log units) above it; measured number inside the range.
By their numbers in this assay, from the lowest: compounds 2, 4, 3 and 1 (each within the scatter of the next, the first and the last beyond it).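

In this assay, replacing 2-(1H-pyrrol-1-yl)ethyl with 4-(methylsulfanyl)benzyl gives a 2.1-fold lower number from compound 1 to compound 4 (0.33 log units; beyond the scatter), a modest step and the only one in the series that can be read across a single change on a saturated chain carbon bound to a sulfonamide nitrogen. Compound 4 carries one six-membered aromatic ring of carbon only, yet its number lies within the scatter of those of compound 2 and compound 3, so among these compounds a group on this position need not be as large as those in compound 2 and compound 3 to reach that range. No supporting data bear on why this change moves the number.

The step alters the ring, the link to the sulfonamide nitrogen and the sulfur-bearing group together, so the share of each in the step stays unresolved. On these data alone, whether the methylsulfanyl group itself contributes remains open, as does the response of this position to an unsubstituted benzyl, a 4-methoxybenzyl, or a benzyl carrying an amine or a carboxylic acid.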